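Compound 3 to compound 4: acetamido for trifluoromethyl

A few compounds are considered here, and "the series" means these few. Any claim that something is new, unique, unknown or untested is made for them only; others in the source may bear on it.

In an ADME assay on L02 cells (Homo sapiens) for cytotoxicity, read by MTT assay, with a stated time of 24 h (on this read-out lower numbers stand for stronger inhibition and higher numbers for weaker inhibition), compound 1 `COc1cc(/C=C2\CN(C)C/C(=C\c3ccncc3)C2=O)cc(OC)c1OC` gives 16400 nM, and compound 2 `COc1ccc(/C=C2\CN(C)C/C(=C\c3ccncc3)C2=O)c(OC)c1OC` gives 15600 nM. Compound 3 `O=C1/C(=C/c2cccnc2)CN(S(=O)(=O)c2ccc(C(F)(F)F)cc2)C/C1=C\c1ccccc1F` gives 11300 nM, which lies within the usual scatter of both other compounds, so these three cannot be ranked on the present numbers.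

Compound 4 `CC(=O)Nc1ccc(S(=O)(=O)N2C/C(=C\c3cccnc3)C(=O)/C(=C/c3ccccc3F)C2)cc1` is still unmeasured. Its difference from compound 3 is acetamido in place of trifluoromethyl on an aromatic carbon, para to a large group.

Within the data shown here, no two measured compounds differ in only one place, so the data give no direct size for this exchange. Among the measured compounds shown here, the only guide is the narrow spread of the series: compound 3 at 11300 nM and compound 1 at 16400 nM differ in more than one place, yet their values remain within the scatter of each other. Three compounds are a thin basis, and this is no established pattern.

The estimated step of a 1.2-fold higher number from compound 3 to compound 4 (0.09 log units; within the scatter) is expected to be small, pointing slightly towards a higher number and not beyond the scatter. For compound 4 the estimated value is 14000 nM, with an expected range from 7000 nM to 30000 nM.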

Compound 4, half-maximal inhibitory concentration: 15600 nM
Beside the measured number, compound 4's estimate is 1.1-fold (0.05 log units) below it; low and high end bracket the measured number.
By their numbers in this assay, from the lowest: compounds 3, 2, 4 and 1 (each within the scatter of the next).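

In this assay, among these compounds, the change from 4-(trifluoromethyl)phenyl to 4-acetamidophenyl gives a 1.4-fold higher number from compound 3 to compound 4 (0.14 log units; within the scatter), the first step between two compounds that differ in one place. At this position, on an aromatic carbon para to a large group, acetamido, with its hydrogen-bond donor and hydrogen-bond acceptor, cannot be told apart on this read-out from trifluoromethyl, which has neither, so the exchange shows no effect that exceeds the scatter. No measurement among the data shown offers any explanation for this outcome.

The compounds shown leave open whether another group on this aromatic carbon, such as an amine, a carboxylic acid or a longer chain, would give a step beyond the scatter, and whether acetamido in place of trifluoromethyl would read the same way on a core other than that of compound 3. All other steps in the series cannot be read, so this assay gives no size yet for a change anywhere else on these compounds.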